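The source may report more compounds than this note shows. Statements on the series, on what has been measured and on what is new or still open speak of the compounds shown alone.

In a functional assay on LOX IMVI cells (Homo sapiens) for cytotoxicity, read by MTT assay, with a stated time of 24 h (on this read-out higher numbers stand for weaker inhibition and lower numbers for stronger inhibition), the series reads as follows

compound 1 `COc1ccc(S(=O)(=O)NCCCNc2nccc(-c3[nH]c(-c4ccccc4)nc3-c3ccc(Cl)c(OC)c3)n2)cc1` gives 1800 nM
compound 2 `O=S(=O)(NCCCNc1nccc(-c2[nH]c(-c3ccccc3)nc2-c2ccc(Cl)c(O)c2)n1)c1ccc(Br)cc1` gives 15500 nM
compound 3 `O=S(=O)(NCCCNc1nccc(-c2[nH]c(-c3ccccc3)nc2-c2ccc(Cl)c(O)c2)n1)c1ccc(F)cc1` gives 2300 nM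
compound 4 `COc1ccc(S(=O)(=O)NCCCNc2nccc(-c3[nH]c(-c4ccccc4)nc3-c3ccc(Cl)c(O)c3)n2)cc1` is not yet measured

Compound 3 at 2300 nM lies within the scatter of compound 1 and well apart from compound 2 on the higher side. Compound 4 follows from compound 3 with methoxy in place of fluoro on an aromatic carbon, para to a large group (methoxy in place of fluoro on an aromatic carbon). Among the compounds with values here, the one measured step at this place is a 6.7-fold lower number from compound 2 to compound 3 (0.83 log units; beyond the scatter) for fluoro in place of bromo, so a change here has moved the number, but that step does not involve methoxy. Compound 1 at 1800 nM also carries the 4-methoxyphenyl group, yet it differs from compound 4 elsewhere, so it is only a loose guide. The step expected in this assay is a 1.1-fold higher number from compound 3 to compound 4 (0.04 log units; within the scatter) and no shift beyond the scatter is foreseen. For compound 4 the estimated value is 2500 nM with an expected range from 900 nM to 7000 nM in this read-out.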

Compound 4, half-maximal inhibitory concentration: 36800 nM
Beside the measured number, compound 4's estimate is 15-fold (1.17 log units) below it; measured number outside the range, above it.
By their numbers in this assay, from the lowest: compounds 1 and 3 (each within the scatter of the next); then compound 2; then compound 4.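

In this assay, this place on the arylsulfonyl side proves more sensitive than the fluoro and bromo pair alone could show: 4-fluorophenyl to 4-methoxyphenyl gives a 16-fold higher number from compound 3 to compound 4 (1.20 log units; beyond the scatter), and methoxy in place of bromo gives a 2.4-fold higher number from compound 2 to compound 4 (0.38 log units; beyond the scatter). Of the three groups seen here, methoxy therefore gives the highest number, with bromo next and fluoro lowest. With the 4-methoxyphenyl group held constant, hydrogen in place of methyl on the oxygen on the aromatic ring gives a 20-fold higher number from compound 1 to compound 4 (1.31 log units; beyond the scatter), so that group does not fix the number on its own.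

Nothing at hand accounts for these steps. Open questions are how an amine or a carboxylic acid would behave at this place, and whether the same oxygen change would act similarly alongside fluoro or bromo.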